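Swapping the Aromatic Group in a Cytotoxicity Series

The compounds below may be only part of what the source reports. "The series", "measured", "known", "first", "only" and "open" are said of these compounds alone.

Of the compounds shown here, three sharing one core have been measured so far. In an ADME assay on J774.A1 cells (Mus musculus) for cytotoxicity, read by MTT assay, with a stated time of 48 h (a higher number here means that more compound is tolerated, a lower number that less compound is tolerated), compound 1 `COC(=O)c1c(NCCCCNc2ccnc3cc(Cl)ccc23)noc1-c1ccc([N+](=O)[O-])cc1` gives 136000 nM, compound 2 `COC(=O)c1c(NCCCCNc2ccnc3cc(Cl)ccc23)noc1-c1ccccc1[N+](=O)[O-]` gives 77700 nM and compound 3 `COC(=O)c1c(NCCCCNc2ccnc3cc(Cl)ccc23)noc1-c1ccccc1F` gives 70900 nM. Compound 3 has no clearly separate place among these numbers. The measured steps to it are a 1.9-fold lower number from compound 1 to compound 3 (0.28 log units; within the scatter) and a 1.1-fold lower number from compound 2 to compound 3 (0.04 log units; within the scatter), so the three cannot be ranked.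

Compound 4 `COC(=O)c1c(NCCCCNc2ccnc3cc(Cl)ccc23)noc1-c1ccc(Cl)cc1Cl` keeps the shared core and carries 2,4-dichlorophenyl in place of 2-fluorophenyl, on an aromatic carbon of a five-membered aromatic ring with 1 nitrogen and 1 oxygen: 2,4-dichlorophenyl in place of 2-fluorophenyl on an aromatic carbon. Among the measured compounds shown here, no measured compound carries the 2,4-dichlorophenyl group, so no measured step shows this exact change. The nearest evidence comes from the swaps at this same place, which also include a 1.8-fold lower number from compound 1 to compound 2 (0.24 log units; within the scatter). All three of these steps stayed small, so no step beyond the scatter is expected in this assay, and no direction can be firmly predicted. The expected step is a 1.1-fold lower number from compound 3 to compound 4 (0.04 log units; within the scatter). The estimate for compound 4 is 65000 nM, with an expected range from 28000 nM to 140000 nM.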

Compound 4, half-maximal cytotoxic concentration: 93600 nM
The estimate for compound 4 lay 1.4-fold (0.16 log units) below the measured number, and the stated range covers the measured number.
By their numbers in this assay, from the lowest: compounds 3, 2, 4 and 1 (each within the scatter of the next).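

Among the compounds shown here, compound 4 is the first in this set with two substituents on the phenyl ring at this aromatic carbon, and 2,4-dichlorophenyl still gives only small steps in this assay (a 1.3-fold higher number from compound 3 to compound 4 (0.12 log units; within the scatter); a 1.2-fold higher number from compound 2 to compound 4 (0.08 log units; within the scatter); a 1.5-fold lower number from compound 1 to compound 4 (0.16 log units; within the scatter)), all of them within the scatter. The four compounds therefore still cannot be truly ranked, and changing the aryl group here, even to one with two chlorine atoms, has produced no clear shift in the tolerated concentration. No measurement shown explains why these swaps leave the number so little changed.

Every group shown at this position is a substituted phenyl ring, so it remains open whether a phenyl ring carrying an amine or a carboxylic acid, or a small alkyl group such as methyl in place of the ring, would give a step beyond the scatter. The same question stands for the rest of the molecule, such as a carboxylic acid in place of the methoxycarbonyl group or a longer chain in the linker.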